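Acrylate ester replacing the amide on the shared core

The source may hold more compounds than are shown below. What is called first, only, known or untested is meant among the compounds shown, and "the series" means these compounds.

Compound 2 `CC(C)NC(=O)c1ccc(-c2nn(Cc3ccccc3)c3ccccc23)cc1` carries an isopropylcarbamoyl group on the shared core of compound 1 `CCCOC(=O)c1ccc(-c2nn(Cc3ccccc3)c3ccccc23)cc1`. In a functional assay on cells (Platelet, Homo sapiens) for inhibition (a lower number here means a stronger inhibitor, a higher number a weaker inhibitor), compound 2 gives only a limit of the assay, > 10000 nM. Compound 1 also gives only a limit in this assay, > 10000 nM. The step that the two limits leave unreadable from compound 1 to compound 2 is thus unreadable, and both values stand at the limit of > 10000 nM in this assay, at which 2 of the 2 values shown sit. Compound 3 `CCOC(=O)/C=C/c1ccc(-c2nn(Cc3ccccc3)c3ccccc23)cc1` carries 2-(ethoxycarbonyl)ethenyl in place of isopropylcarbamoyl on an aromatic carbon. Going by the values given here, no measured step bears on this change, so the expected step of a number no higher from compound 2 to compound 3 (the limit leaves the size open) has no measured anchor. Compound 3 is estimated at 10000 nM, range 3000 nM to 30000 nM, most likely again only a limit.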

Compound 3, half-maximal inhibitory concentration: > 10000 nM
Compound 3 gave a limit, no number; the forecaster's own chance of this, stated with the estimate: 70%; the middle value lies on the limit itself.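

No step among compound 1, compound 2 and compound 3 can be read in this assay, as each gives only a limit: the limit of > 10000 nM in this assay, at which 3 of the 3 values shown sit.

The compounds shown leave open which group on the shared core, if any, would give a measurable value in this assay.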